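The source may report more compounds than this note shows. Statements on the series, on what has been measured and on what is new or still open speak of the compounds shown alone.

Measured so far:
compound 1 `CN(C)S(=O)(=O)c1ccccc1Nc1cc(-c2ccc3ccn(C)c3c2)c2nccnc2c1` — 2 ug/mL
compound 2 `CN1CCCC(NS(=O)(=O)c2ccccc2Nc2cc(-c3ccc4ccn(C)c4c3)c3nccnc3c2)C1` — 9 ug/mL
compound 3 `Cn1ccc2ccc(-c3cc(Nc4cnccc4C(=O)NCc4cncnc4)cc4nccnc34)cc21` — 233 ug/mL

In a physicochemical assay for solubility, read by spectrophotometry, measured as kinetic solubility, at pH 8, tested at 500 uM (on this read-out higher numbers stand for higher solubility and lower numbers for lower solubility), compound 3 stands highest of the three; compound 2 gives 9 ug/mL and compound 1 gives 2 ug/mL, both far lower and beyond the scatter. Compound 4 `CN1CCC(CNC(=O)c2ccncc2Nc2cc(-c3ccc4ccn(C)c4c3)c3nccnc3c2)C1` differs from compound 3 in one place: 1-methylpyrrolidin-3-yl in place of pyrimidin-5-yl on a saturated chain carbon bound to an amide-type nitrogen. Within the data shown here, the only measured step that bears on it is a 4.5-fold higher number from compound 1 to compound 2 (0.65 log units; beyond the scatter), where a group built on a saturated ring carrying one nitrogen also entered; that step was modest. A similar direction is expected here, yet compound 3 already sits so high that little room remains, so a 1.1-fold lower number from compound 3 to compound 4 (0.02 log units; within the scatter) is expected to stay within the scatter. Compound 4 is estimated at 220 ug/mL, range 140 ug/mL to 245 ug/mL.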

Compound 4, solubility: 246 ug/mL
Compound 4: middle estimate off by 1.1-fold (0.05 log units), on the low side; the measured number lies above the stated range.
By their numbers in this assay, from the lowest: compound 1; then compound 2; then compounds 3 and 4 (each within the scatter of the next).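

At the saturated chain carbon bound to an amide-type nitrogen, 1-methylpyrrolidin-3-yl in place of pyrimidin-5-yl gives a 1.1-fold higher number from compound 3 to compound 4 (0.02 log units; within the scatter) in this assay. On this read-out, a non-aromatic five-membered ring and an aromatic six-membered ring are thus interchangeable at this position, unlike the change on a sulfonyl sulfur, where a 4.5-fold higher number from compound 1 to compound 2 (0.65 log units; beyond the scatter) lies beyond the scatter. No measurement here explains why the two groups read alike. Still open, going by these compounds, is whether this level holds with a carboxylic acid in place of 1-methylpyrrolidin-3-yl, or with a longer chain on the amide-type nitrogen.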